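The compounds below may be only part of what the source reports. "The series", "measured", "known", "first", "only" and "open" are said of these compounds alone.

In a functional assay on MDA-MB-231 cells (Homo sapiens) for inhibition, read by MTT assay, with stated times of 18 h and 4 h (a higher number here means a weaker inhibitor, a lower number a stronger inhibitor), compound 3 `CCCCCCOP(=O)(O)OCCSC(=S)N1CCCC1` gives 54000 nM. Compound 2 `CCCCCCCCCCOP(=O)(O)OCCSC(=S)N1CCN(C)CC1` gives 29000 nM, and these two values lie within the usual scatter of each other. Compound 1 `CCCCCCCCCCCCCCCCOP(=O)(O)OCCSC(=S)N1CCN(C)CC1` is reported only as a limit of the assay, > 100000 nM.

Compound 4 `CCCCCCOP(=O)(O)OCCSC(=S)N1CCN(C)CC1` keeps the chain of compound 3 and differs from it in one place: 4-methylpiperazin-1-yl in place of pyrrolidin-1-yl on a thiocarbonyl carbon. In words, 4-methylpiperazin-1-yl stands in place of pyrrolidin-1-yl on a thiocarbonyl carbon.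

For the measured compounds named here, the one measured step, an at least 3.4-fold lower number from compound 1 to compound 2 (0.53 log units; beyond the scatter), shortens the chain and leaves the ring group untouched, so it bears on this change only indirectly. Going by the values given here, no measured pair isolates the ring swap. The closest hint is that compound 2, which already carries 4-methylpiperazin-1-yl, gives 29000 nM, close to compound 3, although the two also differ in chain.

The expected change, a 1.2-fold lower number from compound 3 to compound 4 (0.08 log units; within the scatter), is therefore none beyond the scatter, in either direction. For compound 4 the estimate is 45000 nM, with an expected range from 20000 nM to 100000 nM.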

Compound 4, half-maximal inhibitory concentration: 73000 nM
Compound 4: middle estimate off by 1.6-fold (0.21 log units), on the low side; low and high end bracket the measured number.
By their numbers in this assay, from the lowest: compounds 2, 3 and 4 (each within the scatter of the next, the first and the last beyond it). At a limit, above all of these: compound 1.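

With the chain held fixed, 4-methylpiperazin-1-yl in place of pyrrolidin-1-yl on a thiocarbonyl carbon gives a 1.4-fold higher number from compound 3 to compound 4 (0.13 log units; within the scatter) and so this assay does not separate these two ring groups on this chain. With the ring group held fixed, the chain does separate compounds: the change in chain gives a 2.5-fold higher number from compound 2 to compound 4 (0.40 log units; beyond the scatter) as a modest step, and together with the earlier step it places compound 2 lowest among the compounds with readable steps. Of the chain steps, an at least 1.3-fold lower number from compound 1 to compound 4 (0.13 log units; that floor lies within the scatter) cannot be read as a size, because the value of compound 1 is a limit: the limit of > 100000 nM in this assay, at which 1 of the 4 values shown sits.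

As far as these compounds go, whether the ring swap would also leave the number within the scatter on the chain of compound 2 remains open. So does the effect of a morpholin-4-yl or piperidin-1-yl group at this place, or of a chain of intermediate length.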